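The source may report more compounds than this note shows. Statements on the series, on what has been measured and on what is new or still open speak of the compounds shown alone.

Measured so far in an ADME assay on MDBK cells (Bos taurus) for cytotoxicity, read by MTT assay, with a stated time of 96 h; a higher number here means that more compound is tolerated, a lower number that less compound is tolerated:
- compound 1, `O=[N+]([O-])c1cccc(/N=N/Nc2cccc([N+](=O)[O-])c2)c1`: > 100000 nM
- compound 2, `O=[N+]([O-])c1ccc(/N=N/N2CCCC2)cc1`: > 100000 nM
- compound 3, `CN(C)CCCN(/N=N/c1cc(F)ccc1F)c1ccccc1`: 25000 nM

In this assay compound 1 gives > 100000 nM, which is a limit of the assay and not a number. Compound 2 gives > 100000 nM, again a limit rather than a number. For the measured compounds named here, compound 3 gives 25000 nM, the only plain number among the three. Compound 2 therefore stands at the limit of > 100000 nM in this assay, at which 2 of the 3 values shown sit, and the bare limit leaves open how far beyond it the true value lies. Going by the values given here, no pair of measured compounds differs in only one place, so no measured step in this assay is available for comparison.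

Compound 4, `Clc1ccc(/N=N/N2CCCC2)cc1`, is not yet measured. It differs from compound 2 by chloro in place of nitro on an aromatic carbon. Among the compounds with values here, with no step of this kind measured, any expectation rests on compound 2 alone, and since compound 2 gives only a limit, the direction of the step in this assay cannot be read from the data. The step is expected to be small, probably none beyond the scatter, with a modest chance of a lower number: expected an at least 1.4-fold lower number from compound 2 to compound 4 (0.15 log units; that floor lies within the scatter). Compound 4 is estimated at 70000 nM, within 20000 nM to 200000 nM, and may well return only a limit again.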

Compound 4, half-maximal cytotoxic concentration: > 100000 nM
Compound 4: only a limit was reported; the forecaster's own chance of this, stated with the estimate: 50%; middle value at least 1.4-fold (0.15 log units) away from the limit.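

In this assay, for the compounds shown here, compound 4 returns only a limit, not a number, as compound 2 does, and no step between compound 2 and compound 4 can be read. The compounds shown leave open how far past that limit either true value lies, and whether chloro in place of nitro changes the tolerated concentration at all.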